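Moving One Fluorine on a Benzyl Group

The compounds below may be only part of what the source reports. "The series", "measured", "known", "first", "only" and "open" are said of these compounds alone.

Three related compounds have been tested so far in an ADME assay on HepG2 cells (Homo sapiens) for cytotoxicity, read by CellTiter-Glo and ATP content, with a stated time of 72 h; a lower number here means that less compound is needed, a higher number that more compound is needed for the effect. Compound 1 `Cc1ccc(N2CCN(C(=O)C3CCN(C(=O)c4ccc(S(C)(=O)=O)c([N+](=O)[O-])c4)CC3)CC2)cc1` gives > 27000 nM, which is a limit of the assay and not a number. Compound 2 `CN(Cc1cccc(F)c1)C(=O)CN(C)C(=O)c1ccc(S(C)(=O)=O)c([N+](=O)[O-])c1`, which carries a 3-fluorophenyl group, gives > 27000 nM, and this too is only a limit. Among the measured compounds shown here, compound 3 `CN(Cc1ccccc1F)C(=O)CNC(=O)c1ccc(S(C)(=O)=O)c([N+](=O)[O-])c1` stands alone as the only compound with a true number, 11400 nM.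

Compound 4 `CN(Cc1cccc(F)c1)C(=O)CNC(=O)c1ccc(S(C)(=O)=O)c([N+](=O)[O-])c1` has not yet been measured. It has the same atoms as compound 3, joined differently: 3-fluorophenyl in place of 2-fluorophenyl on a saturated chain carbon bound to an amide-type nitrogen. In words, 3-fluorophenyl takes the place of 2-fluorophenyl on a saturated chain carbon bound to an amide-type nitrogen. For the measured compounds named here, no measured pair yet shows what such a change does, so the expectation starts from compound 3 at 11400 nM. No change beyond the usual scatter is expected in this assay, and the estimated step is a 1.1-fold higher number from compound 3 to compound 4 (0.06 log units; within the scatter). The expected value for compound 4 is 13000 nM, within an estimated range of 6000 nM to 27000 nM.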

Compound 4, half-maximal effective concentration: > 27000 nM
Compound 4 gave a limit, no number; the forecaster's own chance of this, stated with the estimate: 30%; at least 2.0-fold (0.31 log units) between middle value and limit.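

3-Fluorophenyl in place of 2-fluorophenyl gives an at least 2.3-fold higher number from compound 3 to compound 4 (0.37 log units; beyond the scatter) in this assay, the first readable effect of a single change in this series. With the same atoms joined differently, the place of one fluorine on the benzyl group therefore matters here, and more compound is needed for the effect with 3-fluorophenyl than with 2-fluorophenyl. The step for hydrogen in place of methyl on the amide-type nitrogen, between compound 2 and compound 4, cannot be read, so that change remains without a measured effect.

From the compounds shown here alone, whether a plain phenyl group, with no fluorine, would behave more like compound 3 or compound 4 stays open. The full size of the fluorine step also stays open because compound 4 gives only a limit, not a number: the limit of > 27000 nM in this assay, at which 3 of the 4 values shown sit.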